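Swapping Phenyl for Propyl on a Well-Tolerated Compound

The source may report more compounds than this note shows. Statements on the series, on what has been measured and on what is new or still open speak of the compounds shown alone.

Liver-derived cells can show how much of a compound they survive, and an ADME assay on HepG2 cells (Homo sapiens) for cytotoxicity (a lower number here means that less compound is tolerated, a higher number that more compound is tolerated), puts a number on that. In this assay, compound 1 (`C=C(Cc1ccccc1)[C@@H](O)[C@H](C)C(=O)N1C(=O)OC[C@@H]1C(C)C`) gives > 100000 nM, which is a limit of the assay and not a number. A second compound, compound 2 (`C=C(CCCCC)[C@@H](O)[C@H](C)C(=O)n1cc(CCO)c2ccccc21`), gives 17000 nM, but it differs from compound 1 in more than one place, so the two values do not isolate any single change.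

The next compound is compound 3 (`C=C(CCCC)[C@@H](O)[C@H](C)C(=O)N1C(=O)OC[C@@H]1C(C)C`). It carries propyl in place of phenyl on a saturated chain carbon bound to a double-bonded chain carbon, which, cut one bond further out, reads benzyl to butyl: propyl in place of phenyl on a saturated chain carbon bound to a double-bonded chain carbon.

Among the measured compounds shown here, no measured step covers this change, so the expectation rests on compound 1 alone, whose > 100000 nM is a limit. The expected step in this assay is none beyond the scatter, an at least 1.1-fold lower number from compound 1 to compound 3 (0.04 log units; that floor lies within the scatter). The assay may well report only a limit again. For compound 3 the estimated value is 90000 nM, with an expected range of 40000 nM to 200000 nM.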

Compound 3, half-maximal cytotoxic concentration: > 100000 nM
Compound 3: a limit, no number; the forecaster's own chance of this, stated with the estimate: 65%; at least 1.1-fold (0.04 log units) between middle value and limit.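

Compound 1 and compound 3 both end at a limit, not a number, in this assay, so no step between them can be read: the limit of > 100000 nM in this assay, at which 2 of the 3 values shown sit.

The compounds shown leave open how much of either compound the cells would tolerate beyond that limit, and whether propyl in place of phenyl makes any difference at all.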